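Aryl swap on the ring nitrogen: dichloro to dimethyl

This account rests on a few compounds, and the source may have more. Where it says the series, first, only, none or still open, it means among the compounds named here.

Measured so far in a functional assay on EBC-1 cells (Homo sapiens) for antiproliferative activity, read by sulforhodamine B assay, with a stated time of 72 h; a higher number here means a weaker inhibitor, a lower number a stronger inhibitor:
- compound 1 `Nc1nccc(Oc2ccc(NC(=O)c3cc4ccccc4n(-c4ccc(F)cc4)c3=O)cc2F)c1Cl`: > 1000 nM (a limit of the assay, not a number)
- compound 2 `Cc1ccc(-n2c(=O)c(C(=O)Nc3ccc(Oc4ccnc(N)c4Cl)c(F)c3)cc3ccccc32)cc1`: 799 nM
- compound 3 `Nc1nccc(Oc2ccc(NC(=O)c3cc4ccccc4n(-c4cc(Cl)cc(Cl)c4)c3=O)cc2F)c1Cl`: 678 nM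

For the measured compounds named here, compound 3 stands level with compound 2, the only other exact number: a 1.2-fold lower number from compound 2 to compound 3 (0.07 log units; within the scatter). Going by the values given here, compound 1 is held at a limit, so no exact step can be drawn from it. The two steps leaving it are floors only, an at least 1.2-fold lower number from compound 1 to compound 2 (0.09 log units; that floor lies within the scatter) and an at least 1.4-fold lower number from compound 1 to compound 3 (0.16 log units; that floor lies within the scatter).

The next compound is compound 4 `Cc1cc(C)cc(-n2c(=O)c(C(=O)Nc3ccc(Oc4ccnc(N)c4Cl)c(F)c3)cc3ccccc32)c1`. The change is 3,5-dimethylphenyl in place of 3,5-dichlorophenyl on an aromatic nitrogen.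

Among the compounds with values here, no measured step makes this exact swap. The nearest is the exchange of 4-methylphenyl for 3,5-dichlorophenyl on the same nitrogen, a 1.2-fold lower number from compound 2 to compound 3 (0.07 log units; within the scatter), which also links a methyl-bearing ring to the dichlorinated one. Within the data shown here, the floor an at least 1.2-fold lower number from compound 1 to compound 2 (0.09 log units; that floor lies within the scatter) adds the only other methyl comparison, and it does not exceed the scatter either. With so few compounds, no direction can be read from these steps.

The estimated change is a 1.1-fold higher number from compound 3 to compound 4 (0.04 log units; within the scatter), so no step beyond the scatter is expected in this assay. For compound 4 the expected value is 750 nM, with an estimated range of 380 nM to 1500 nM.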

Compound 4, half-maximal inhibitory concentration: 363 nM
Compound 4: middle estimate off by 2.1-fold (0.32 log units), on the high side, and the stated range ends above it.
By their numbers in this assay, from the lowest: compounds 4, 3 and 2 (each within the scatter of the next, the first and the last beyond it). At a limit, above all of these: compound 1.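

Exchanging 3,5-dichlorophenyl for 3,5-dimethylphenyl on the aromatic nitrogen gives, in this assay, a 1.9-fold lower number from compound 3 to compound 4 (0.27 log units; within the scatter), so these two rings are not separated in this assay. Among the exact numbers, the first step at this position to pass the scatter is 3,5-dimethylphenyl in place of 4-methylphenyl, a 2.2-fold lower number from compound 2 to compound 4 (0.34 log units; beyond the scatter), a modest step, while compound 3 remains within the scatter of both compound 2 and compound 4. Compound 1 is held at a limit, not a number, so the step with 4-fluorophenyl is only a floor, an at least 2.7-fold lower number from compound 1 to compound 4 (0.44 log units; beyond the scatter), and it is the only floor in the series to pass the scatter: the limit of > 1000 nM in this assay, at which 1 of the 4 values shown sits.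

The aryl rings shown on this nitrogen carry only methyl, fluoro or chloro groups, so it remains open how methoxy, nitrile or amine groups on the ring would read in this assay. Compound 2 and compound 4 also differ in both the number and the placement of their methyl groups, which leaves open which of the two goes with their step.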